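Formyl in place of vinyl on the quinolinone series

The source may hold more compounds than are shown below. What is called first, only, known or untested is meant among the compounds shown, and "the series" means these compounds.

Measured so far:
compound 1 `C=CCn1c(-c2ccc(OC)cc2C=C)cc2ccccc2c1=O`: 22800 nM
compound 2 `C=CCn1c(-c2cc(OC)c(OC)cc2COCOC)cc2ccccc2c1=O`: 78700 nM

Of the compounds shown here, two of the shared core have been tested in a functional assay on HCT-15 cells (Homo sapiens) for cytotoxicity, read by MTT assay, with a stated time of 48 h; a higher number here means a weaker inhibitor, a lower number a stronger inhibitor. Compound 1 gives 22800 nM and holds the lowest of the two numbers. Compound 2 gives 78700 nM in this assay, a higher number, and the gap between compound 1 and compound 2 is beyond the scatter. For the measured compounds named here, the two compounds differ in more than one place, so no single step is read from them.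

Compound 3 `C=CCn1c(-c2ccc(OC)cc2C=O)cc2ccccc2c1=O` has not been measured. It differs from compound 1 only at the position described here: formyl in place of vinyl on an aromatic carbon. The change keeps the heavy-atom count and the one double bond outside aromatic rings, and adds one hydrogen-bond acceptor. Going by the values given here, nothing among the measured compounds speaks to this exchange, so no direction can be drawn from the data.

For compound 3 the step from compound 1 is expected to be small, a 1.0-fold lower number from compound 1 to compound 3 (0.02 log units; within the scatter), within the scatter in either direction. The estimate for compound 3 in this assay is 22000 nM, expected to fall between 7000 nM and 70000 nM.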

Compound 3, half-maximal inhibitory concentration: 56500 nM
Estimate against measurement, compound 3: 2.6-fold (0.41 log units) below; the range from low to high includes it.
By their numbers in this assay, from the lowest: compound 1; then compounds 3 and 2 (each within the scatter of the next).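

In this assay, for the compounds shown here, formyl in place of vinyl on an aromatic carbon, ortho to a large group and meta to a methoxy group, gives a 2.5-fold higher number from compound 1 to compound 3 (0.39 log units; beyond the scatter), the only step so far that can be read at a single place. This shows that the position is not indifferent to the exchange, although the step is modest: the two groups have the same heavy-atom count and each carries one double bond outside aromatic rings, yet vinyl gives the lower number in this matched pair, and the entering formyl adds one hydrogen-bond acceptor and swaps one carbon for oxygen. Nothing at hand accounts for the step, and one pair sets no trend beyond compound 1 and compound 3.

Still open, from the compounds shown here alone, is whether an amine, a carboxylic acid or a longer chain on this aromatic carbon would move the number below that of compound 1 or further above it. Also open, going by these compounds, is whether the same exchange gives a step of similar size when the methoxy pattern on the ring differs, as it does in compound 2.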